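From Methoxy to Methyl: Expecting Compound 3

The source may hold more compounds than are shown below. What is called first, only, known or untested is meant among the compounds shown, and "the series" means these compounds.

Compound 2 `COc1ccc(/C=C/C(=O)/C=C/C2=C(C)CCCC2(C)C)cc1` has been tested in a functional assay on Hep cells (Homo sapiens) for cytotoxicity, read by sulforhodamine B assay, with a stated time of 48 h; a higher number here means a weaker inhibitor, a lower number a stronger inhibitor. For compound 2 the result there is a limit, > 100000 nM, not a number. Its closest measured relative is compound 1 `CC1=C(/C=C/C(=O)/C=C/c2ccc(F)cc2)C(C)(C)CCC1`, which in this assay gives 55800 nM. Among the compounds with values here, the one measured step, an at least 1.7-fold higher number from compound 1 to compound 2 (0.25 log units; that floor lies within the scatter), is an exchange of fluoro for methoxy, and its true size is uncertain because of the limit of > 100000 nM in this assay, at which 1 of the 2 values shown sits. Compound 3 `CC1=C(/C=C/C(=O)/C=C/c2ccc(C)cc2)C(C)(C)CCC1` differs from compound 2 by methyl in place of methoxy on an aromatic carbon. Within the data shown here, no measured step shows methyl against methoxy, so the only guide is the fluoro-to-methoxy step, which points to weak inhibition in both measured compounds. For compound 3 the expected step is an at least 1.2-fold lower number from compound 2 to compound 3 (0.09 log units; that floor lies within the scatter), within the scatter. In this assay compound 3 is therefore estimated at 80000 nM, with a range from 40000 nM to 160000 nM.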

Compound 3, half-maximal inhibitory concentration: 44100 nM
Beside the measured number, compound 3's estimate is 1.8-fold (0.26 log units) above it; the range from low to high includes it.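

Moving from methoxy to methyl, on an aromatic carbon para to a large group, gives an at least 2.2-fold lower number from compound 2 to compound 3 (0.35 log units; beyond the scatter), the first step at this position that lies beyond the scatter, though its true size stays uncertain because the value of compound 2 is a limit: the limit of > 100000 nM in this assay, at which 1 of the 3 values shown sits. Fluoro and methyl, by contrast, are not told apart at this position, with a 1.3-fold lower number from compound 1 to compound 3 (0.10 log units; within the scatter). Methoxy is thus separated from methyl, while the floor of its step from fluoro remains within the scatter, so the change in group matters here only for this one pair.

The compounds shown leave open how an amine, a hydroxyl or a carboxylic acid at this position would read in this assay. They also leave open whether any group here would bring the number far below those of compound 1 and compound 3.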